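The source may hold more compounds than are shown below. What is called first, only, known or untested is meant among the compounds shown, and "the series" means these compounds.

Measured so far in a functional assay on NCI/ADR-RES cells (Homo sapiens) for inhibition, read by sulforhodamine B assay, with a stated time of 48 h; a lower number here means a stronger inhibitor of growth, a higher number a weaker inhibitor of growth:

- compound 1 `CC1(/C=C/c2ccc(C(F)(F)F)cc2)C=CC(=O)O1` gives 9400 nM
- compound 2 `COc1c(O)ccc(/C=C/C2(C)C=CC(=O)O2)c1OC` gives 51600 nM

Compound 1 holds the lower of these two numbers, which makes it the stronger inhibitor of growth of the pair, and the gap to compound 2 lies beyond the scatter. The next compound to be tested is compound 3 `CC1(/C=C/c2ccc(O)cc2)C=CC(=O)O1`. It keeps the core of compound 1 and differs in one place, with hydroxy in place of trifluoromethyl on an aromatic carbon. For the measured compounds named here, no measured pair shows this exchange on its own, so the expectation rests on thin evidence. Going by the values given here, the only hint is compound 2, which also carries a hydroxy on its aromatic ring and gives 51600 nM, although it differs from compound 1 in more than one place. A moderate step towards weaker growth inhibition in this assay, probably beyond the scatter, is therefore expected. The expected change is a 3.0-fold higher number from compound 1 to compound 3 (0.47 log units; beyond the scatter). Compound 3 is estimated at 28000 nM, with an expected range of 9000 nM to 80000 nM.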

Compound 3, concentration for total growth inhibition: 111000 nM
The estimate for compound 3 lay 4.0-fold (0.60 log units) below the measured number; the measured number lies above the stated range.
By their numbers in this assay, from the lowest: compound 1; then compound 2; then compound 3.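

In this assay, for the compounds shown here, the exchange of trifluoromethyl for hydroxy on an aromatic carbon, para to a group of 9 heavy atoms, gives a 12-fold higher number from compound 1 to compound 3 (1.07 log units; beyond the scatter) and is the first change that can be read on its own. It shows that, with the core of compound 1 held fixed, growth inhibition depends strongly on which group sits at this place, and that hydroxy here goes with a much weaker inhibitor of growth than trifluoromethyl. The exchange alters several things together, as 4 heavy atoms with no hydrogen-bond donor leave and 1 heavy atom with 1 hydrogen-bond donor and 1 hydrogen-bond acceptor enters, and no measurement available here bears on why the number rises.

Going by these compounds, with only these two groups compared at this place, it remains open where a chlorine, a methoxy, an amine or a nitrile would fall on the span that this step opens. On these data alone, it is also open whether the same exchange would give a step of similar size at another place on the ring, or on a core carrying a longer chain in place of the methyl.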